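Rearranging the same atoms on a quinoline-like core

A few compounds are considered here, and "the series" means these few. Any claim that something is new, unique, unknown or untested is made for them only; others in the source may bear on it.

Of the compounds shown here, three sharing one core have been tested in an assay on isolated protein for inhibition of P-selectin glycoprotein ligand 1 (Homo sapiens), read by surface plasmon resonance, tested at 250 uM; on this read-out higher numbers stand for more inhibition at the one concentration tested (going by the name of the read-out) and lower numbers for less inhibition. Compound 1 `CC(C)(c1ccccc1)c1nc2c(C(F)(F)F)cccc2c(C(=O)O)c1O` gives 59%, the highest number of the three; compound 3 `CC(C)C(c1ccccc1)c1nc2c(C(F)(F)F)cccc2c(C(=O)O)c1O` sits within the usual scatter of it with 58%, while compound 2 `COc1ccc(C2(c3nc4c(C(F)(F)F)cccc4c(C(=O)O)c3O)CC2)cc1` gives 26%, a number that falls well beyond the scatter from compound 1. The two groups that keep inhibition high in compound 1 and compound 3 are both branched carbon groups carrying a phenyl ring; compound 2 differs in several places at once, so no single cause for its drop can be read from these numbers.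

Compound 4 `CC(Cc1ccccc1)c1nc2c(C(F)(F)F)cccc2c(C(=O)O)c1O` has not yet been measured. It keeps every atom of compound 1 but joins them differently: 1-benzylethyl in place of 1-methyl-1-phenylethyl on an aromatic carbon. Because compound 1 gives 59% and compound 3, with another branched phenyl-bearing group in the same place, gives 58%, the expectation is that this change costs little, with a step from compound 1 to compound 4 of a number 9 percentage points lower from compound 1 to compound 4 (within the scatter) in this assay. Compound 4 is therefore estimated at 50%, within a range from 30% to 68%.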

Compound 4, a percentage reported as inhibition, at one concentration (the size of the read-out at that concentration, not a potency): 49%
The estimate for compound 4 lay 1 percentage points above the measured number; the measured number falls inside the stated range.
By their numbers in this assay, from the lowest: compound 2; then compounds 4, 3 and 1 (each within the scatter of the next).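

In this assay, replacing 1-methyl-1-phenylethyl with 1-benzylethyl on the aromatic carbon next to the ring nitrogen gives a step of a number 10 percentage points lower from compound 1 to compound 4 (within the scatter). Among these compounds, this is the first comparison here in which only one place differs, and it shows that this position can take a different joining of the same carbon atoms, with the phenyl ring kept, without a change beyond the usual scatter. No measurement shown here explains this result.

Still open is whether the phenyl ring matters at this position, as the compounds shown do not tell how a tert-butyl group, which has no ring, would compare. They also leave open the result for a longer chain such as 3-phenylpropyl, or for an amine in this place.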